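The source may hold more compounds than are shown below. What is called first, only, known or untested is meant among the compounds shown, and "the series" means these compounds.

Measured in an ADME assay on MT4 cells (Homo sapiens) for cytotoxicity, read by MTT assay, with a stated time of 5 days; on this read-out lower numbers stand for higher toxicity in this test and higher numbers for lower toxicity in this test:
compound 1, `Cc1cc(C)cc(S(=O)(=O)c2c(C(=O)N[C@H]3CCNC3)[nH]c3ccc(Cl)cc23)c1`: 10000 nM
compound 2, `Cc1cc(C)cc(S(=O)(=O)c2c(C(=O)N[C@H]3CCN(S(C)(=O)=O)C3)[nH]c3ccc(Cl)cc23)c1`: 29900 nM
compound 3, `Cc1cc(C)cc(S(=O)(=O)c2c(C(=O)N[C@H]3CCN(CC(N)=O)C3)[nH]c3ccc(Cl)cc23)c1`: 28100 nM

Compound 3 stands second highest of the three numbers; its nearest neighbour is compound 2, within the scatter, and its furthest is compound 1, reached by a 2.8-fold higher number from compound 1 to compound 3 (0.45 log units; beyond the scatter).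

Compound 4 is `Cc1cc(C)cc(S(=O)(=O)c2c(C(=O)NS(=O)(=O)c3ccc(F)cc3)[nH]c3ccc(Cl)cc23)c1`. The change from compound 3 is (4-fluorophenyl)sulfonyl in place of 1-(carbamoylmethyl)pyrrolidin-3-yl on an amide-type nitrogen. All measured steps alter only the amine nitrogen in the ring: a 3.0-fold higher number from compound 1 to compound 2 (0.48 log units; beyond the scatter) and a 2.8-fold higher number from compound 1 to compound 3 (0.45 log units; beyond the scatter) were modest, and a 1.1-fold lower number from compound 2 to compound 3 (0.03 log units; within the scatter) lay within the scatter. None removes that ring group from the amide-type nitrogen, so they bear only loosely on this step. A small shift in this assay is therefore expected, possibly none beyond the scatter. Compound 4 is estimated at 20000 nM, between 6000 nM and 60000 nM, meaning an expected step of a 1.4-fold lower number from compound 3 to compound 4 (0.15 log units; within the scatter).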

Compound 4, half-maximal cytotoxic concentration: > 252000 nM
Compound 4 was reported as a limit; the forecaster's own chance of this, stated with the estimate: 30%; middle value at least 12-fold (1.10 log units) away from the limit.
By their numbers in this assay, from the lowest: compound 1; then compounds 3 and 2 (each within the scatter of the next). At a limit, above all of these: compound 4.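

Compound 4 is reported only as a limit in this assay: the limit of > 252000 nM in this assay, at which 1 of the 4 values shown sits.

Placing (4-fluorophenyl)sulfonyl on the amide-type nitrogen in place of the ring group gives an at least 8.9-fold higher number from compound 3 to compound 4 (0.95 log units; beyond the scatter), an at least 8.4-fold higher number from compound 2 to compound 4 (0.92 log units; beyond the scatter) and an at least 25-fold higher number from compound 1 to compound 4 (1.40 log units; beyond the scatter). The earlier compounds shown here varied only the amine nitrogen in the ring, whereas this change shows that the amide-type nitrogen can move the number further towards lower toxicity in this test.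

Compound 4 alone cannot separate the part played by the sulfonyl link from that of the fluorine-bearing ring. A phenylsulfonyl or benzoyl group on that nitrogen would address this.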